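Amide aryl variation on the shared core: nitrile replaces methyl

The source may hold more compounds than are shown below. What is called first, only, known or untested is meant among the compounds shown, and "the series" means these compounds.

Compound 1 `O=C(Nc1cccc(-c2oc3cc(-c4ccc(F)cc4)ccc3c(=O)c2O)c1)c1ccc(Br)cc1` and compound 2 `Cc1cccc(C(=O)Nc2cccc(-c3oc4cc(-c5ccc(F)cc5)ccc4c(=O)c3O)c2)c1` share one core and differ only in the aryl group on the carbonyl carbon. In a functional assay on HeLa cells (Homo sapiens) for antiproliferative activity, read by CCK-8 assay, with a stated time of 72 h (a higher number here means a weaker inhibitor, a lower number a stronger inhibitor), compound 1 gives 9740 nM and compound 2 gives 6650 nM; compound 2 has the lowest of the two numbers, but the step of a 1.5-fold lower number from compound 1 to compound 2 (0.17 log units; within the scatter) lies within the scatter. Compound 3 `N#Cc1ccc(C(=O)Nc2cccc(-c3oc4cc(-c5ccc(F)cc5)ccc4c(=O)c3O)c2)cc1` carries 4-cyanophenyl in place of 3-methylphenyl on a carbonyl carbon. For the measured compounds named here, the only measured step at this place, a 1.5-fold lower number from compound 1 to compound 2 (0.17 log units; within the scatter), was small, so for compound 3 no step beyond the scatter is expected: a 1.1-fold higher number from compound 2 to compound 3 (0.05 log units; within the scatter). Compound 3 is estimated at 7500 nM, with a range of 3000 nM to 19000 nM.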

Compound 3, half-maximal inhibitory concentration: 23300 nM
The estimate for compound 3 lay 3.1-fold (0.49 log units) below the measured number; measured number outside the range, above it.
By their numbers in this assay, from the lowest: compounds 2 and 1 (each within the scatter of the next); then compound 3.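

The aryl group on the carbonyl carbon does affect the read-out in this assay (a 3.5-fold higher number from compound 2 to compound 3 (0.54 log units; beyond the scatter)), a step beyond the scatter, unlike the step between the two earlier compounds. Cyano in place of bromo on an aromatic carbon also raises the number (a 2.4-fold higher number from compound 1 to compound 3 (0.38 log units; beyond the scatter)), so 4-cyanophenyl stands apart from both earlier aryl groups. Nothing available explains this shift.

Open, going by these compounds, is whether an amine or a carboxylic acid on this aryl group would stay near compound 2 or move further from it. With a single nitrile compound, the effect of the nitrile cannot be separated from that of its place on the ring.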